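Swapping dimethylamino for hydroxy on the side chain

The source may report more compounds than this note shows. Statements on the series, on what has been measured and on what is new or still open speak of the compounds shown alone.

Measured in a functional assay on LNCaP cells (Homo sapiens) for cytotoxicity; a lower number here means a stronger inhibitor, a higher number a weaker inhibitor:
- Compound 1 (`CNC(=O)Nc1ccc(-c2nc(N3CC4CCC(C3)O4)c3cnn(C(C)C)c3n2)cc1`): 5 nM
- Compound 2 (`CNC(=O)Nc1ccc(-c2nc(N3CC4CCC(C3)O4)c3cnn(CCN(C)C)c3n2)cc1`): 400 nM

Compound 2 has the higher number of the two. Among the measured compounds shown here, the only measured step, an 80-fold higher number from compound 1 to compound 2 (1.90 log units; beyond the scatter), is large and beyond the scatter. Compound 3 (`CNC(=O)Nc1ccc(-c2nc(N3CC4CCC(C3)O4)c3cnn(CCO)c3n2)cc1`) differs from compound 2 by hydroxy in place of dimethylamino on a saturated chain carbon, two bonds along the chain from an aromatic nitrogen, with hydroxy in place of dimethylamino. For the measured compounds named here, no measured step covers this exchange directly, but that one step replaced isopropyl with 2-(dimethylamino)ethyl, so a sizeable move back toward compound 1 is expected in this assay, though not all the way. The expected change is an 8.0-fold lower number from compound 2 to compound 3 (0.90 log units; beyond the scatter). Compound 3 is estimated at 50 nM, within a range of 10 nM to 250 nM.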

Compound 3, half-maximal inhibitory concentration: 650 nM
Compound 3: the middle estimate sits 13-fold (1.11 log units) below what was measured; measured number above the stated range.
By their numbers in this assay, from the lowest: compound 1; then compounds 2 and 3 (each within the scatter of the next).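

In this assay, hydroxy in place of dimethylamino on the side chain gives a 1.6-fold higher number from compound 2 to compound 3 (0.21 log units; within the scatter), which is within the scatter, so these two end groups cannot be told apart here. The 2-hydroxyethyl group also stands well apart from isopropyl, with a 130-fold higher number from compound 1 to compound 3 (2.11 log units; beyond the scatter), so the large step at this aromatic nitrogen is not tied to dimethylamino alone. Nothing at hand accounts for this result. The compounds shown leave open whether a plain ethyl or propyl group on that nitrogen would stay close to compound 1 or to compound 3. They also leave open how a carboxylic acid or a longer chain would behave there.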